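Shortening the chain from compound 2 to compound 3

This account rests on a few compounds, and the source may have more. Where it says the series, first, only, none or still open, it means among the compounds named here.

In a physicochemical assay for solubility, in phosphate buffer, at pH 7.4 (a higher number here means a more soluble compound, a lower number a less soluble compound), compound 1 `COCCOCCOCCOCCOCCOCCOCCOCCOCCOCCOC(=O)Oc1c(C(C)C)cccc1C(C)C` reports only a limit, > 314000 ug/mL, and not a number. Within the data shown here, compound 2 `COCCOCCOCCOCCOCCOCCOC(=O)Oc1c(C(C)C)cccc1C(C)C` gives 830 ug/mL, the only actual number so far. Compound 3 `COCCOCCOCCOCCOC(=O)Oc1c(C(C)C)cccc1C(C)C` has not yet been measured. Its structure departs from compound 2 by one change: hydrogen in place of (2-methoxyethoxy)methyl on a saturated chain carbon bound to an oxygen on a saturated carbon. Among the measured compounds shown here, one measured step bears on this, an at least 370-fold lower number from compound 1 to compound 2 (2.57 log units; beyond the scatter), a large change beyond the scatter whose size is only a bound. That step also put hydrogen in place of a chain at the same kind of place, but the group leaving now is smaller. A smaller drop in the same direction is therefore expected. The expected change is a 14-fold lower number from compound 2 to compound 3 (1.14 log units; beyond the scatter), which would still lie beyond the scatter. For compound 3 the estimated value is 60 ug/mL, with an expected range from 10 ug/mL to 300 ug/mL.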

Compound 3, solubility: 380 ug/mL
Beside the measured number, compound 3's estimate is 6.3-fold (0.80 log units) below it; measured number above the stated range.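

In this assay, the loss of (2-methoxyethoxy)methyl gives a 2.2-fold lower number from compound 2 to compound 3 (0.34 log units; beyond the scatter), the first step along this chain with a number at both ends. Compound 1 gave only a bound on the step that followed it, because its value is a limit and not a number: the limit of > 314000 ug/mL in this assay, at which 1 of the 3 values shown sits. The same kind of change, hydrogen in place of a chain on a saturated chain carbon bound to an oxygen on a saturated carbon, keeps its direction here, and its size now has a measured value rather than a bound.

The compounds shown leave open how the number moves with a chain shorter than that of compound 3, and where along the longer chains the large change sets in. They also leave open what an amine or a carboxylic acid on the chain would do.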